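The compounds below may be only part of what the source reports. "The series", "measured", "known", "first", "only" and "open" are said of these compounds alone.

Measured compounds in a functional assay on A375P cells (Homo sapiens) for antiproliferative activity, read by MTT assay, with a stated time of 48 h; on this read-out lower numbers stand for stronger inhibition and higher numbers for weaker inhibition:

Compound 1, `Nc1cccc2c(-c3cccc(NC(=O)c4ccc(Cl)cc4C(F)(F)F)c3)ccnc12`: > 20000 nM (a limit of this assay)
Compound 2, `CC(=O)Nc1cccc2c(-c3cccc(NC(=O)c4ccc(C)c(C)c4)c3)ccnc12`: > 20000 nM (a limit of this assay)
Compound 3, `CC(=O)Nc1cccc2c(-c3cccc(NC(=O)c4ccc(Cl)c(C(F)(F)F)c4)c3)ccnc12`: 2400 nM

Among the measured compounds shown here, compound 3 is the only member of this small set that gives a number in this assay; the other two values are limits. Compound 1 reaches only the limit (the limit of > 20000 nM in this assay, at which 2 of the 3 values shown sit). Compound 2 likewise sits at that limit. For the measured compounds named here, the single step that can be sized, an at least 8.3-fold lower number from compound 2 to compound 3 (0.92 log units; beyond the scatter), shows that the aryl group on the carbonyl carbon has a strong influence on the read-out.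

Compound 4, `CC(=O)Nc1cccc2c(-c3cccc(NC(=O)c4ccc(Cl)cc4C(F)(F)F)c3)ccnc12`, has not been measured. It differs from compound 3 only in that aryl group: 4-chloro-2-(trifluoromethyl)phenyl in place of 4-chloro-3-(trifluoromethyl)phenyl on a carbonyl carbon. Going by the values given here, the same 4-chloro-2-(trifluoromethyl)phenyl group is carried by compound 1, which also bears a free amine instead of the acetamide on the shared core, so no single-change step links it to compound 3 or compound 4; its value shows only that this group, in that setting, gives no number.

Given that the aryl change in an at least 8.3-fold lower number from compound 2 to compound 3 (0.92 log units; beyond the scatter) moved the read-out well beyond the scatter, a shift of the trifluoromethyl is expected to matter here too, most likely toward a weaker compound. Compound 4 is therefore expected to give 12000 nM, within 3000 nM to 40000 nM, which means an expected step of a 5.0-fold higher number from compound 3 to compound 4 (0.70 log units; beyond the scatter).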

Compound 4, half-maximal inhibitory concentration: > 20000 nM
Compound 4 gave a limit, no number (the forecaster's own chance of this, stated with the estimate: 45%); middle value at least 1.6-fold (0.22 log units) away from the limit.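

In this assay, among the compounds shown here, putting 4-chloro-2-(trifluoromethyl)phenyl in place of 4-chloro-3-(trifluoromethyl)phenyl on the carbonyl carbon gives an at least 8.3-fold higher number from compound 3 to compound 4 (0.92 log units; beyond the scatter), so the one number in this set is lost with no atom gained or removed. The earlier step exchanged a 3,4-dimethylphenyl group for a group with different atoms, so it could not separate which atoms the aryl group carries from how they are joined; this pair holds the atoms fixed and shows that the joining alone is enough to move the read-out beyond the scatter. The true size of the step stays open, as compound 4 gives a limit and not a number: the limit of > 20000 nM in this assay, at which 3 of the 4 values shown sit.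

The steps from compound 2 and from compound 1 to compound 4 cannot be read, as both ends of each are limits, so the effect of acetyl in place of hydrogen on the nitrogen stays unsized. Also open, going by these compounds, are whether the 4-chloro-3-(trifluoromethyl)phenyl group keeps a number with the free amine on the shared core, and how a nitrile or a methoxy group in place of the trifluoromethyl would read.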